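Pyrazole in Place of Trifluoromethyl: Solubility Outlook

A few compounds are considered here, and "the series" means these few. Any claim that something is new, unique, unknown or untested is made for them only; others in the source may bear on it.

Of the compounds shown here, three sharing one core have been measured in a physicochemical assay for solubility; on this read-out lower numbers stand for lower solubility and higher numbers for higher solubility. Compound 1, `COCCCn1c(=O)[nH]c2c(N)nc(C(F)(F)F)cc21`, gives 23 ug/mL. Compound 2, `Cc1ccc(Cn2c(=O)[nH]c3c(N)nc(C(F)(F)F)cc32)cn1`, gives 22 ug/mL, and compound 3, `Cc1cccc(Cn2c(=O)[nH]c3c(N)nc(C(F)(F)F)cc32)n1`, gives 3 ug/mL. Compound 2 thus stands second highest of the three numbers: compound 1 lies within the scatter of it, while the step of a 7.3-fold lower number from compound 2 to compound 3 (0.87 log units; beyond the scatter) is the widest gap in the set. The step of a 7.7-fold lower number from compound 1 to compound 3 (0.88 log units; beyond the scatter) is of similar size, and a 1.0-fold lower number from compound 1 to compound 2 (0.02 log units; within the scatter) stays within the scatter.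

Compound 4, `Cc1ccc(Cn2c(=O)[nH]c3c(N)nc(-n4cccn4)cc32)cn1`, differs from compound 2 in a single place: 1H-pyrazol-1-yl in place of trifluoromethyl on an aromatic carbon. None of the three measured steps concerns this position; each of them exchanges the group on the saturated chain carbon bound to an aromatic nitrogen, leaving the new change without a direct precedent. On that basis a small step of a 1.4-fold higher number from compound 2 to compound 4 (0.13 log units; within the scatter) of uncertain direction is expected. Compound 4 is therefore estimated at 30 ug/mL, with a range from 8 ug/mL to 90 ug/mL.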

Compound 4, solubility: 45 ug/mL
Compound 4: middle estimate off by 1.5-fold (0.18 log units), on the low side; low and high end bracket the measured number.
By their numbers in this assay, from the lowest: compound 3; then compounds 2, 1 and 4 (each within the scatter of the next, the first and the last beyond it).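

In this assay, the aromatic carbon next to the ring nitrogen now has a measured exchange of its own: 1H-pyrazol-1-yl in place of trifluoromethyl gives a 2.0-fold higher number from compound 2 to compound 4 (0.31 log units; beyond the scatter) and no longer leaves this position without a precedent. The earlier steps shown here all concerned the group on the saturated chain carbon, whereas this one shows that a change on the aromatic carbon, swapping a group with no ring for a five-membered aromatic ring with 2 hetero atoms, can also move the number beyond the scatter. Nothing available accounts for the size or direction of this step.

The exchange is shown only with the 6-methylpyridin-3-yl group of compound 2, so its size alongside the 2-methoxyethyl of compound 1 or the 6-methylpyridin-2-yl of compound 3 remains open. Also open, from the compounds shown here alone, is how a nitrile, an amine or a methoxy group would read on this aromatic carbon.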